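Cyano replacing dimethylamino with solubility at the assay limit

The compounds below may be only part of what the source reports. "The series", "measured", "known", "first", "only" and "open" are said of these compounds alone.

Compound 1 `Cc1cc(NCc2ccccn2)n2ncc(-c3ccc(F)cc3)c2n1`: in a physicochemical assay for solubility, read by HPLC, using the shake flask method, measured as kinetic solubility, with a stated time of 2 h, at pH 7.4 (on this read-out higher numbers stand for higher solubility and lower numbers for lower solubility), compound 1 gives only a limit, < 5000 nM.
Compound 2 `Cc1ccc(-c2cnn3c(NCc4ccccn4)cc(C)nc23)cc1`: in this assay compound 2 gives only a limit, < 5000 nM.
Compound 3 `Cc1cc(NCc2ccccn2)n2ncc(-c3ccc(N(C)C)cc3)c2n1`: in this assay compound 3 gives only a limit, < 5000 nM.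

Compound 3 therefore stands where every measured compound stands, at the limit of < 5000 nM in this assay, at which 3 of the 3 values shown sit. The steps a step that the two limits leave unreadable from compound 1 to compound 2, a step that the two limits leave unreadable from compound 1 to compound 3 and a step that the two limits leave unreadable from compound 2 to compound 3 cannot be sized. Compound 4 `Cc1cc(NCc2ccccn2)n2ncc(-c3ccc(C#N)cc3)c2n1` differs from compound 3 by cyano in place of dimethylamino on an aromatic carbon. Going by the values given here, since no measured step has a readable size or direction, the measured compounds give no ground to expect a step beyond the scatter in this assay. Compound 4 is thus expected to give about 2500 nM in this assay, within 300 nM to 9000 nM. The step that the limit leaves unreadable from compound 3 to compound 4 is an estimate only, and a further limit is the likeliest outcome.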

Compound 4, solubility: < 5000 nM
Compound 4 ended at the assay's limit (the forecaster's own chance of this, stated with the estimate: 75%); the middle value lies beyond the limit too.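

Compound 4 also gives only a limit, so its steps from compound 1, compound 2 and compound 3 cannot be read in this assay: the limit of < 5000 nM in this assay, at which 4 of the 4 values shown sit.

The compounds shown leave open how the solubilities of these four compounds compare with one another.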